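The source may hold more compounds than are shown below. What is called first, only, known or untested is meant among the compounds shown, and "the series" means these compounds.

Measured so far:
Compound 1, `COc1ccc(C(=O)c2cc(OC)c(OC)c(OC)c2)cc1NC(=O)/C=C/c1cc(OC)c(OC)c(OC)c1` — 1500 nM
Compound 2, `COc1cccc(/C=C/C(=O)Nc2cc(C(=O)c3cc(OC)c(OC)c(OC)c3)ccc2OC)c1` — 3100 nM

Both compounds share a core in which a trimethoxybenzoyl-bearing ring carries an amide linked to a cinnamoyl chain. Among the measured compounds shown here, in a functional assay on HeLa cells (Homo sapiens) for cytotoxicity, read by MTT assay, with a stated time of 72 h (on this read-out lower numbers stand for stronger inhibition and higher numbers for weaker inhibition), compound 1 gives 1500 nM, and compound 2 gives 3100 nM, the higher of the two values, meaning the weaker inhibition; the only measured step, a 2.1-fold higher number from compound 1 to compound 2 (0.32 log units; beyond the scatter), shows that changing the aryl group at the end of the double-bonded chain shifts the read-out by a modest amount.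

Compound 3, `C#CCOc1cccc(/C=C/C(=O)Nc2cc(C(=O)c3cc(OC)c(OC)c(OC)c3)ccc2OC)c1`, has not yet been measured. It differs from compound 2 by ethynyl in place of hydrogen on a saturated chain carbon bound to an oxygen on an aromatic ring, so the methoxy on that phenyl becomes a propargyloxy. For the measured compounds named here, no measured step covers this kind of change: the only step known alters the substitution pattern of that same phenyl, not the size of a single alkoxy group. Compound 3 is therefore expected to stay close to compound 2 in this assay, with a step of a 1.0-fold lower number from compound 2 to compound 3 (0.01 log units; within the scatter) that most likely falls within the usual scatter. The estimate for compound 3 is 3000 nM, with a plausible range from 1000 nM to 9000 nM.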

Compound 3, half-maximal inhibitory concentration: 14000 nM
For compound 3 the middle estimate is 4.7-fold (0.67 log units) below the measured one, outside the stated range (above it).
By their numbers in this assay, from the lowest: compound 1; then compound 2; then compound 3.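

In this assay, turning the methoxy of the 3-methoxyphenyl group into a propargyloxy gives a 4.5-fold higher number from compound 2 to compound 3 (0.65 log units; beyond the scatter), which is larger than the earlier step of a 2.1-fold higher number from compound 1 to compound 2 (0.32 log units; beyond the scatter). A change to a single alkoxy group on this phenyl therefore weakens inhibition by more than the change in methoxy groups between the first two compounds did, and replacing the 3,4,5-trimethoxyphenyl outright with 3-(propargyloxy)phenyl gives a 9.3-fold higher number from compound 1 to compound 3 (0.97 log units; beyond the scatter). Nothing measured here explains why the number rises when ethynyl takes the place of hydrogen at this position.

The compounds shown leave open whether the weaker result goes with the triple bond or simply with a longer chain, a question that a propoxy group, which has the chain but no triple bond, could help to answer. Also open, going by these compounds, is how a smaller or differently built group on the same phenyl, such as an ethoxy, a hydroxyl or an amine, would read in this assay.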